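From Bromo to (Benzylsulfonyl)amino: An Expected Cytotoxicity Step

The source may report more compounds than this note shows. Statements on the series, on what has been measured and on what is new or still open speak of the compounds shown alone.

Within the data shown here, compound 2 `O=C(Nc1nc(-c2cccc(Br)c2)cs1)c1ccc([N+](=O)[O-])o1` is one of two compounds so far tested in an ADME assay on Vero cells (Chlorocebus sabaeus) for cytotoxicity, read by MTT assay, with a stated time of 72 h (on this read-out lower numbers stand for stronger inhibition and higher numbers for weaker inhibition), and in that test compound 2 gives 71000 nM. Compound 1 `O=C(Nc1nc(-c2ccccc2)cs1)c1ccc([N+](=O)[O-])o1` gives 41700 nM in this assay. The step of a 1.7-fold higher number from compound 1 to compound 2 (0.23 log units; within the scatter) stays within the scatter, so compound 2 holds the higher of the two numbers but cannot be told apart from compound 1.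

Compound 3 `O=C(Nc1nc(-c2cccc(NS(=O)(=O)Cc3ccccc3)c2)cs1)c1ccc([N+](=O)[O-])o1` has not been measured. It differs from compound 2 by (benzylsulfonyl)amino in place of bromo on an aromatic carbon. Among the measured compounds shown here, only the single step of a 1.7-fold higher number from compound 1 to compound 2 (0.23 log units; within the scatter) bears on this change, and it covers a much smaller group entering at the same aromatic carbon. For the measured compounds named here, no measured step covers a group of this size, so the expectation rests on the two numbers standing close together. Compound 3 is therefore expected to move little, a step of a 1.2-fold lower number from compound 2 to compound 3 (0.07 log units; within the scatter). The estimate for compound 3 is 60000 nM, with a range from 20000 nM to 150000 nM.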

Compound 3, half-maximal inhibitory concentration: 59300 nM
Beside the measured number, compound 3's estimate is 1.0-fold (0.01 log units) above it; the range from low to high includes it.
By their numbers in this assay, from the lowest: compounds 1, 3 and 2 (each within the scatter of the next).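

In this assay, (benzylsulfonyl)amino in place of bromo gives a 1.2-fold lower number from compound 2 to compound 3 (0.08 log units; within the scatter), and the same group in place of hydrogen gives a 1.4-fold higher number from compound 1 to compound 3 (0.15 log units; within the scatter). At this aromatic carbon, meta to a large group, hydrogen, bromo and (benzylsulfonyl)amino therefore cannot be told apart, which the step from hydrogen to bromo could not show, as only one heavy atom enters there, whereas this group brings in a further six-membered aromatic ring and a hydrogen-bond donor. On these data alone, whether an amine, a carboxylic acid or a longer chain at the same carbon would also stay within the scatter remains open. No measurement among these compounds explains why the three cannot be told apart.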